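This account rests on a few compounds, and the source may have more. Where it says the series, first, only, none or still open, it means among the compounds named here.

In a functional assay on HL-60 cells (Homo sapiens) for cytotoxicity, read by MTT assay (a higher number here means a weaker inhibitor, a lower number a stronger inhibitor), compound 1 `Cc1ccccc1S(=O)(=O)NC(C1=CC(=O)c2c(O)ccc(O)c2C1=O)C(C)C` gives 190 nM and compound 3 `COc1ccc(S(=O)(=O)NC(C2=CC(=O)c3c(O)ccc(O)c3C2=O)C(C)C)c(OC)c1` gives 400 nM as the higher of the two numbers, which makes it the weaker inhibitor of this pair. For compound 2 `COc1ccc(S(=O)(=O)NC(C2=CC(=O)c3c(O)ccc(O)c3C2=O)C(C)C)cc1` the record reads "not determined" (no result reported) and offers no number. Compound 4 `COc1ccc(S(=O)(=O)NC(C)C2=CC(=O)c3c(O)ccc(O)c3C2=O)c(OC)c1` carries methyl in place of isopropyl on a saturated chain carbon bound to a double-bonded ring carbon and a sulfonamide nitrogen. Within the data shown here, the only measured step, a 2.1-fold higher number from compound 1 to compound 3 (0.32 log units; beyond the scatter) and modest in size, changes the group on the sulfonyl sulfur, a different place. Among the measured compounds shown here, no measured step touches this chain, so no direction can be read for this assay and no shift beyond the scatter is expected. The expected outcome is a 1.1-fold lower number from compound 3 to compound 4 (0.06 log units; within the scatter) and nothing larger. For compound 4 the estimated value is 350 nM (130 nM to 950 nM).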

Compound 4, half-maximal inhibitory concentration: 500 nM
The estimate for compound 4 lay 1.4-fold (0.15 log units) below the measured number; the measured number falls inside the stated range.
By their numbers in this assay, from the lowest: compound 1; then compounds 3 and 4 (each within the scatter of the next).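

In this assay, methyl in place of isopropyl on this saturated chain carbon gives a 1.3-fold higher number from compound 3 to compound 4 (0.10 log units; within the scatter), so at this position the swap leaves the number within the scatter. Among these compounds, this is the first reading at this chain carbon, since the earlier step changed only the group on the sulfonyl sulfur. Nothing available explains why the number holds here. Still open, as far as these compounds go, is whether a longer chain, an amine or a carboxylic acid at this carbon would shift the number, and whether the same swap would behave alike with the 2-methylphenyl group of compound 1.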